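Dichlorophenyl replaces methoxyphenyl on the pyrazole nitrogen

A few compounds are considered here, and "the series" means these few. Any claim that something is new, unique, unknown or untested is made for them only; others in the source may bear on it.

Measured compounds:
compound 1, `COc1ccc(-n2ncc(C(=O)Nc3ccc(C(F)(F)F)cc3)c2C)cc1`: 340 nM
compound 2, `Cc1cccc(-n2ncc(C(=O)Nc3ccc(C(F)(F)F)cc3)c2C)c1`: 2500 nM
compound 3, `COc1cccc(-n2ncc(C(=O)Nc3ccc(C(F)(F)F)cc3)c2C)c1`: 2500 nM

All three share one core and differ only in the aryl group on an aromatic nitrogen. In a functional assay with Homo sapiens as the target (on this read-out lower numbers stand for stronger inhibition and higher numbers for weaker inhibition), compound 1 gives 340 nM. Compound 3 gives 2500 nM in this assay, level with compound 2 at the digits shown, and the two together hold the highest numbers of the three; the move from compound 1 is a 7.4-fold higher number from compound 1 to compound 3 (0.87 log units; beyond the scatter), and from compound 2 to compound 3 there is no change at the digits printed from compound 2 to compound 3 (within the scatter).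

Compound 4, `Cc1c(C(=O)Nc2ccc(C(F)(F)F)cc2)cnn1-c1cccc(Cl)c1Cl`, is not yet measured. Its change from compound 3 is 2,3-dichlorophenyl in place of 3-methoxyphenyl on an aromatic nitrogen. Within the data shown here, no measured step swaps a 3-methoxyphenyl for a chlorinated ring, so the nearest guidance is the pair of steps a 7.4-fold higher number from compound 1 to compound 2 (0.87 log units; beyond the scatter) and a 7.4-fold higher number from compound 1 to compound 3 (0.87 log units; beyond the scatter), which show that the aryl group can move the number by a modest amount, while no change at the digits printed from compound 2 to compound 3 (within the scatter) shows that exchanging one small group for another at the same spot can leave it unchanged. The expected step from compound 3 is therefore small, a 1.3-fold lower number from compound 3 to compound 4 (0.10 log units; within the scatter), with either direction possible. Compound 4 is estimated at 2000 nM, in the range 500 nM to 8000 nM.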

Compound 4, half-maximal inhibitory concentration: 1600 nM
Estimate against measurement, compound 4: 1.3-fold (0.10 log units) above; the measured number falls inside the stated range.
By their numbers in this assay, from the lowest: compound 1; then compounds 4, 2 and 3 (each within the scatter of the next).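

Swapping in two chlorines does not separate this ring from the singly substituted rings in this assay: replacing 3-methoxyphenyl gives a 1.6-fold lower number from compound 3 to compound 4 (0.19 log units; within the scatter) and replacing 3-methylphenyl gives a 1.6-fold lower number from compound 2 to compound 4 (0.19 log units; within the scatter), so 2,3-dichlorophenyl, 3-methoxyphenyl and 3-methylphenyl cannot be told apart here. Replacing 4-methoxyphenyl gives a clearer result, a 4.7-fold higher number from compound 1 to compound 4 (0.67 log units; beyond the scatter), so among the four aryl groups on this aromatic nitrogen, 4-methoxyphenyl alone gives a number set apart from all the others, and that now holds against a chlorinated ring as well as against rings bearing methyl or methoxy. The data offered here give no reason for this difference.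

With both chlorines arriving in a single change, these compounds cannot show what either chlorine contributes alone, or whether a phenyl ring carrying only one chlorine would behave like compound 4. On these data alone, it also remains open whether the low number of compound 1 is special to methoxy, or whether a phenyl ring carrying an amine, a carboxylic acid or a longer ether chain would give a similar number.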